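The source may report more compounds than this note shows. Statements on the series, on what has been measured and on what is new or still open speak of the compounds shown alone.

Of the compounds shown here, three built on the same core have been measured in an assay for inhibition of 3-hydroxy-3-methylglutaryl-coenzyme A reductase (Rattus norvegicus); on this read-out lower numbers stand for stronger inhibition and higher numbers for weaker inhibition. Compound 1 `CC(=O)O[C@H]1C[C@@H](C)C=C2C=C[C@H](C)[C@H](CCC3C[C@@H](O)CC(=O)O3)[C@H]21` gives 269 nM. Compound 2 `C[C@H]1C=C2C=C[C@H](C)[C@H](CCC3C[C@@H](O)CC(=O)O3)[C@H]2[C@@H](OCc2ccc(F)cc2)C1` gives 4.7 nM. Compound 3 `C=CCO[C@H]1C[C@@H](C)C=C2C=C[C@H](C)[C@H](CCC3C[C@@H](O)CC(=O)O3)[C@H]21` gives 370 nM. Compound 3 therefore shows the highest number of the three, although its gap to compound 1 lies within the scatter, whereas a 79-fold higher number from compound 2 to compound 3 (1.90 log units; beyond the scatter).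

Compound 4 `C[C@H]1C=C2C=C[C@H](C)[C@H](CCC3C[C@@H](O)CC(=O)O3)[C@H]2[C@@H](OCc2ccccc2)C1` differs from compound 3 in one place: phenyl in place of vinyl on a saturated chain carbon bound to an oxygen on a saturated carbon. The step that bears most directly on this is a 79-fold higher number from compound 2 to compound 3 (1.90 log units; beyond the scatter), which is the same change run backwards, except that the ring entering there carried a fluorine. The other step, a 57-fold lower number from compound 1 to compound 2 (1.76 log units; beyond the scatter), points the same way: a 4-fluorobenzyl at this place goes with a much lower number than acetyl. A large drop is therefore expected for compound 4, a 46-fold lower number from compound 3 to compound 4 (1.67 log units; beyond the scatter), landing near compound 2 with some allowance for the absent fluorine. Compound 4 is estimated at 8 nM, with a range of 3 nM to 25 nM.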

Compound 4, half-maximal inhibitory concentration: 27 nM
Beside the measured number, compound 4's estimate is 3.4-fold (0.53 log units) below it; the whole stated range lies below it.
By their numbers in this assay, from the lowest: compound 2; then compound 4; then compounds 1 and 3 (each within the scatter of the next).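

In this assay the ring without any fluorine already accounts for much of the gain at this oxygen, since phenyl in place of vinyl gives a 14-fold lower number from compound 3 to compound 4 (1.14 log units; beyond the scatter) and benzyl in place of acetyl gives a 10-fold lower number from compound 1 to compound 4 (1.00 log units; beyond the scatter) as well. The fluorine still counts. Hydrogen in place of fluoro on an aromatic carbon gives a 5.7-fold higher number from compound 2 to compound 4 (0.76 log units; beyond the scatter), and so one atom on the ring moves the number beyond the scatter. Nothing available explains why the ring or the fluorine has these effects.

Still open, from the compounds shown here alone, is whether chlorine or a methoxy group in the place of that fluorine would match or beat it. Also open, going by these compounds, is whether a phenylethyl or pyridylmethyl group on this oxygen would keep the number this low.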